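The source may report more compounds than this note shows. Statements on the series, on what has been measured and on what is new or still open speak of the compounds shown alone.

Compound 1 `C=CC[C@H]1C[C@]2([C@@H](C)Cc3cc(OC)c(OC)cc3F)OCOC2=CC1=O`: 120 nM
Compound 2 `C=CC[C@H]1C[C@]2([C@@H](C)Cc3cc(C)c(OC)cc3F)OCOC2=CC1=O`: 650 nM

Within the data shown here, in a functional assay on NCI-H460 cells (Homo sapiens) for antiproliferative activity, with a stated time of 72 h (a higher number here means a weaker inhibitor, a lower number a stronger inhibitor), compound 2 carries the higher of these two numbers, separated from its only neighbour by a 5.4-fold higher number from compound 1 to compound 2 (0.73 log units; beyond the scatter). Compound 3 `C=CC[C@H]1C[C@]2([C@@H](C)Cc3cc(C#N)c(OC)cc3F)OCOC2=CC1=O` differs from compound 2 by cyano in place of methyl on an aromatic carbon. Among the measured compounds shown here, no measured step exchanges methyl for cyano; the single step at this aromatic carbon, a 5.4-fold higher number from compound 1 to compound 2 (0.73 log units; beyond the scatter), shows only that a change there can move the number beyond the scatter, without fixing a direction for cyano. Compound 3 is therefore estimated at 350 nM, with an expected range from 100 nM to 1200 nM. This expected step, a 1.9-fold lower number from compound 2 to compound 3 (0.27 log units; within the scatter), remains uncertain.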

Compound 3, half-maximal inhibitory concentration: 150 nM
Compound 3: middle estimate off by 2.3-fold (0.37 log units), on the high side, and the stated range covers the measured number.
By their numbers in this assay, from the lowest: compounds 1 and 3 (each within the scatter of the next); then compound 2.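

In this assay, this aromatic carbon, ortho to a methoxy group, now shows that methyl is not simply tolerated or disfavoured by any substituent there: cyano in place of methyl gives a 4.3-fold lower number from compound 2 to compound 3 (0.64 log units; beyond the scatter) and so recovers what methyl lost. Cyano in place of methoxy gives a 1.3-fold higher number from compound 1 to compound 3 (0.10 log units; within the scatter) and leaves the two groups indistinguishable, with methyl alone standing apart. No evidence on the reason for this is at hand. On these data alone, whether an amine, a hydroxyl or a chloro group at this carbon would fall with cyano and methoxy or with methyl stays open.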